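This account rests on a few compounds, and the source may have more. Where it says the series, first, only, none or still open, it means among the compounds named here.

Measured so far:
compound 1 `CNC(=O)c1ccncc1Nc1cc(-c2ccc3ccn(C)c3c2)c2nccnc2c1` — 7020 nM
compound 2 `Cn1cc(CNC(=O)c2ccncc2Nc2cc(-c3ccc4ccn(C)c4c3)c3nccnc3c2)cn1` — 75900 nM

In an assay on lysate for inhibition of 6-phosphofructo-2-kinase/fructose-2,6-bisphosphatase 3 (Homo sapiens), with stated times of 0.5 min and 45 min (on this read-out lower numbers stand for stronger inhibition and higher numbers for weaker inhibition), compound 2 stands highest of the two numbers; its nearest neighbour is compound 1, and the step of an 11-fold higher number from compound 1 to compound 2 (1.03 log units; beyond the scatter) lies beyond the scatter. Compound 3 `CN1CCC(NC(=O)c2ccncc2Nc2cc(-c3ccc4ccn(C)c4c3)c3nccnc3c2)CC1` differs from compound 2 in one place: 1-methylpiperidin-4-yl in place of (1-methyl-1H-pyrazol-4-yl)methyl on an amide-type nitrogen. Among the compounds with values here, no measured step covers this swap directly; the only step on the amide nitrogen, an 11-fold higher number from compound 1 to compound 2 (1.03 log units; beyond the scatter), shows that enlarging the substituent there cost potency. Within the data shown here, with no closer precedent, compound 3 is expected to stay weak in this assay, estimated at 40000 nM (range 8000 nM to 200000 nM), a step of a 1.9-fold lower number from compound 2 to compound 3 (0.28 log units; within the scatter) that may well fall within the scatter.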

Compound 3, half-maximal inhibitory concentration: 19500 nM
Beside the measured number, compound 3's estimate is 2.1-fold (0.31 log units) above it, within the range that was stated.
By their numbers in this assay, from the lowest: compound 1; then compound 3; then compound 2.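

At the amide-type nitrogen, heavy-atom count alone does not settle the read-out in this assay: 1-methylpiperidin-4-yl and (1-methyl-1H-pyrazol-4-yl)methyl have the same count, yet the swap gives a 3.9-fold lower number from compound 2 to compound 3 (0.59 log units; beyond the scatter) in favour of the piperidine. Even so, the gain does not restore the methyl result, with a 2.8-fold higher number from compound 1 to compound 3 (0.44 log units; beyond the scatter) remaining, so methyl keeps the lowest number of the three groups. No available evidence accounts for these differences.

Still open, as far as these compounds go, is how the bare amide hydrogen, an ethyl or a cyclopropyl group would compare with methyl. Also open, from the compounds shown here alone, is whether a piperidin-4-yl without its methyl group, or a morpholine ring, would shift the number from that of compound 3.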